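Changing the Side Chain of Compound 2

The source may hold more compounds than are shown below. What is called first, only, known or untested is meant among the compounds shown, and "the series" means these compounds.

In an ADME assay on S9 fraction from liver (Rattus norvegicus, strain Sprague-Dawley) for metabolic stability, read by LC-MS, using NADPH, with stated times of 5 min and 60 min, tested at 5 uM (on this read-out higher numbers stand for a more stable compound and lower numbers for a less stable compound), compound 2 `COc1cc(C2CN(C(=O)c3cc(OC[C@@H](O)CO)ccn3)C2)ccc1OCc1ccc(C2CC2)cc1` gives 61%. Compound 3 `CCc1ccc(COc2ccc(C3CN(C(=O)c4cc(COCC(CO)(CO)CO)ccn4)C3)cc2OC)cc1` gives 58%, within the usual scatter of compound 2. Compound 1 `COc1ccc(COc2ccc(C3CN(C(=O)c4cc(OCCO)ccn4)C3)cc2OC)cc1` gives 49%, lower than compound 2 by more than the scatter. Compound 4 `COc1cc(C2CN(C(=O)c3cc(COCC(CO)CO)ccn3)C2)ccc1OCc1ccc(C2CC2)cc1` has not yet been measured. It differs from compound 2 in one place: (3-hydroxy-2-(hydroxymethyl)propoxy)methyl in place of 2,3-dihydroxypropoxy on an aromatic carbon. A (3-hydroxy-2-(hydroxymethyl)propoxy)methyl group stands in place of 2,3-dihydroxypropoxy on an aromatic carbon. Among the compounds with values here, no measured pair shows this change alone, so the expectation rests on the nearby values of compound 2, at 61%, and compound 3, at 58%. The expected change, a number 3 percentage points lower from compound 2 to compound 4 (within the scatter), stays within the scatter. Compound 4 is estimated at 58%, with an expected range of 46% to 70%.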

Compound 4, percent of the compound remaining: 29%
Compound 4: the middle estimate sits 29 percentage points above what was measured; measured number outside the range, below it.
By their numbers in this assay, from the lowest: compound 4; then compounds 1, 3 and 2 (each within the scatter of the next, the first and the last beyond it).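

In this assay, this aromatic carbon opposite the ring nitrogen proves sensitive to the side chain: (3-hydroxy-2-(hydroxymethyl)propoxy)methyl in place of 2,3-dihydroxypropoxy gives a number 32 percentage points lower from compound 2 to compound 4 (beyond the scatter), a large step. Both groups carry the same counts of hydrogen-bond donors and acceptors, so those counts alone do not track stability in this pair. Nothing available explains the drop. On these data alone, whether the larger chain, its branching or its link to the ring matters remains open. As far as these compounds go, how an amine or a carboxylic acid would behave at this position also remains open.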